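Cyanophenyl shift from compound 2 to compound 4

This account rests on a few compounds, and the source may have more. Where it says the series, first, only, none or still open, it means among the compounds named here.

In a functional assay on MIA PaCa-2 cells (Homo sapiens) for inhibition, read by MTT assay, with a stated time of 72 h, tested at 50 uM (on this read-out higher numbers stand for more inhibition of growth at the one concentration tested and lower numbers for less inhibition of growth), compound 1 (`C=CCc1cc(O)c(O)c(CN2CCC(CCO)CC2)c1`) stands at 71.8% and compound 3 (`C#CCOc1ccc(CC=C)cc1O`) at 30.3% with compound 2 (`C=CCc1ccc(OCc2cn(-c3ccc(C#N)cc3)nn2)c(O)c1`) second of the three at 45.9% and both of its gaps beyond the scatter. Compound 4 (`C=CCc1ccc(OCc2cn(-c3cccc(C#N)c3)nn2)c(O)c1`) carries 3-cyanophenyl in place of 4-cyanophenyl on an aromatic nitrogen and keeps the same atoms, joined differently. Within the data shown here, no measured pair isolates a change of this kind, so the expectation stays anchored on compound 2 at 45.9% with no direction favoured. The expected step of a number 0.1 percentage points higher from compound 2 to compound 4 (within the scatter) stays within the scatter. The estimate for compound 4 is 46% (expected range 33% to 59%).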

Compound 4, percent growth inhibition at one concentration: 41.6%
Compound 4: middle estimate off by 4.4 percentage points, on the high side, within the range that was stated.
By their numbers in this assay, from the lowest: compound 3; then compounds 4 and 2 (each within the scatter of the next); then compound 1.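

In this assay, among these compounds, the move to 3-cyanophenyl in place of 4-cyanophenyl on an aromatic nitrogen gives a number 4.3 percentage points lower from compound 2 to compound 4 (within the scatter) and provides the first one-place comparison. On this read-out, at the one concentration tested, the two cyanophenyl groups on this nitrogen are not told apart. No measured evidence bears on this result.

Still open, going by these compounds, is whether a phenyl carrying a carboxylic acid or an amine on this nitrogen would differ from compound 2 beyond the scatter. Also open, on these data alone, is whether the two cyanophenyl compounds stay alike at other concentrations.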